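The source may report more compounds than this note shows. Statements on the series, on what has been measured and on what is new or still open speak of the compounds shown alone.

Compound 1 `N#CC1(c2cc(CCO)cc(-c3ccnc4[nH]nc(C(F)(F)F)c34)c2)CC1` gives 25 nM in an assay on isolated protein for inhibition of protein kinase C epsilon type (Homo sapiens), read by coupled enzyme assay; a higher number here means a weaker inhibitor, a lower number a stronger inhibitor.
Compound 2 `C[C@@H](O)Cc1cc(-c2ccnc3[nH]nc(C(F)(F)F)c23)cc(C2(C#N)CC2)c1` gives 34 nM in this assay.
Compound 3 `CC(=O)OCCc1cc(-c2ccnc3[nH]nc(C(F)(F)F)c23)cc(C2(C#N)CC2)c1` gives 119 nM in this assay.

Compound 3 has the highest number of the three, and so is the weakest inhibitor among them; its steps to compound 2 and to compound 1 both lie beyond the scatter. Compound 4 `N#CC1(c2cc(CC(=O)O)cc(-c3ccnc4[nH]nc(C(F)(F)F)c34)c2)CC1` is not yet measured. It differs from compound 3 in one place: carboxy in place of acetoxymethyl on a saturated chain carbon bound to an aromatic carbon. Among the measured compounds shown here, two measured steps touch this part of the molecule. Adding an acetyl group gave a 4.8-fold higher number from compound 1 to compound 3 (0.68 log units; beyond the scatter), and swapping the chain end gave a 3.5-fold higher number from compound 2 to compound 3 (0.54 log units; beyond the scatter). Neither step reverses the change now made, which removes the acetyl group and shortens the chain while bringing in a hydrogen-bond donor, so the direction is uncertain, though the weakening seen on acetylation of compound 1 suggests the number may fall again. Compound 4 is therefore expected to give about 60 nM in this assay, within 15 nM to 250 nM, an expected step of a 2.0-fold lower number from compound 3 to compound 4 (0.30 log units; within the scatter).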

Compound 4, inhibition constant: 446 nM
Compound 4: middle estimate off by 7.4-fold (0.87 log units), on the low side; the measured number lies above the stated range.
By their numbers in this assay, from the lowest: compounds 1 and 2 (each within the scatter of the next); then compound 3; then compound 4.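

In this assay, carboxy on this saturated chain carbon bound to an aromatic carbon is the most damaging change shown, with an 18-fold higher number from compound 1 to compound 4 (1.25 log units; beyond the scatter) in place of hydroxymethyl and a 13-fold higher number from compound 2 to compound 4 (1.12 log units; beyond the scatter) in place of 1-hydroxyethyl as the two largest steps in the set. Carboxy carries a hydrogen-bond donor that acetoxymethyl lacks, yet replacing acetoxymethyl still gives a 3.7-fold higher number from compound 3 to compound 4 (0.57 log units; beyond the scatter) and does not recover the lower numbers of compound 1 and compound 2. Compound 4 is therefore the weakest inhibitor of the four, and the earlier rise on acetylation did not mark the limit of what this position can lose.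

No measurement here explains why carboxy does so poorly. On these data alone, it remains open whether an amide or an amine at this chain end would behave like hydroxymethyl or like carboxy, and whether a longer chain ending in a carboxylic acid would change the result.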